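Butyl Ester Expected to Share the Limit of Its Neighbours

The source may report more compounds than this note shows. Statements on the series, on what has been measured and on what is new or still open speak of the compounds shown alone.

Compound 2 `C/C=C1/[C@H](O[C@@H]2O[C@H](CO)[C@@H](O)[C@H](O)[C@H]2O)OC=C(C(=O)OC)[C@H]1CC(=O)OCCc1ccc(F)cc1` carries a 2-(4-fluorophenyl)ethyl ester on the shared core. In a functional assay on SK-BR-3 cells (Homo sapiens) for antiproliferative activity, read by MTT assay, with a stated time of 72 h (a lower number here means a stronger inhibitor, a higher number a weaker inhibitor), compound 2 gives only a limit, > 20000 nM. Compound 1 `C/C=C1/[C@H](O[C@@H]2O[C@H](CO)[C@@H](O)[C@H](O)[C@H]2O)OC=C(C(=O)OC)[C@H]1CC(=O)OCCC` is the propyl-ester counterpart. In this assay compound 1 also gives only a limit, > 15000 nM. For the measured compounds named here, the single measured step, a step that the two limits leave unreadable from compound 1 to compound 2, cannot be read, since the limit of > 15000 nM in this assay, at which 1 of the 2 values shown sits, and the limit of > 20000 nM in this assay, at which 1 of the 2 values shown sits, show that both values sit at limits.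

Compound 3 `C/C=C1/[C@H](O[C@@H]2O[C@H](CO)[C@@H](O)[C@H](O)[C@H]2O)OC=C(C(=O)OC)[C@H]1CC(=O)OCCCC` is the butyl ester; its difference from compound 2 is ethyl in place of 4-fluorophenyl on a saturated chain carbon, two bonds along the chain from an oxygen next to a carbonyl group. No readable step bears on this change. Because the limit of > 15000 nM in this assay, at which 1 of the 2 values shown sits, and the limit of > 20000 nM in this assay, at which 1 of the 2 values shown sits, place both neighbours at limits, compound 3 is expected to return a limit as well in this assay. The expected step is estimated as a step that the limit leaves unreadable from compound 2 to compound 3, nothing beyond the scatter. Compound 3 is thus estimated at 25000 nM, within 10000 nM to 60000 nM.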

Compound 3, half-maximal inhibitory concentration: > 15000 nM
Compound 3 gave a limit, no number; the forecaster's own chance of this, stated with the estimate: 85%; the middle value is on the limit's open side.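

Compound 3, like compound 1 and compound 2, gives only a limit in this assay, so the steps joining compound 3 to compound 1 and compound 2 cannot be read. The compounds shown leave open what actual value any of these three esters would reach in this assay.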